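Ketone oxazole series: aryl replaced by methylcarbamoyl

The compounds below may be only part of what the source reports. "The series", "measured", "known", "first", "only" and "open" are said of these compounds alone.

Measured compounds:
compound 1 `Nc1ccc(-c2cnc(C(=O)CCCCCCc3ccccc3)o2)cc1` — 90 nM
compound 2 `N#Cc1ccc(-c2cnc(C(=O)CCCCCCc3ccccc3)o2)cc1` — 40 nM
compound 3 `Cc1cccc(-c2cnc(C(=O)CCCCCCc3ccccc3)o2)n1` — 3.3 nM

In an assay (Rattus norvegicus) for inhibition of Fatty-acid amide hydrolase 1 (Homo sapiens) (on this read-out higher numbers stand for weaker inhibition and lower numbers for stronger inhibition), compound 3 gives the lowest number of the three. Its nearest neighbour is compound 2, with a 12-fold lower number from compound 2 to compound 3 (1.08 log units; beyond the scatter) lying beyond the scatter; compound 1 sits furthest, with a 27-fold lower number from compound 1 to compound 3 (1.44 log units; beyond the scatter). Both steps swap one six-membered aromatic ring for another at the same ring carbon, and both are large.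

Compound 4 `CNC(=O)c1cnc(C(=O)CCCCCCc2ccccc2)o1` is not yet measured. The change from compound 3 is methylcarbamoyl in place of 6-methylpyridin-2-yl on an aromatic carbon. The group that leaves carries one six-membered aromatic ring; the group that enters has no ring and brings one hydrogen-bond donor. Among the measured compounds shown here, no measured step removes the aromatic ring at this position, so the two large steps of a 27-fold lower number from compound 1 to compound 3 (1.44 log units; beyond the scatter) and a 12-fold lower number from compound 2 to compound 3 (1.08 log units; beyond the scatter) bear only indirectly: they show that what stands on this ring carbon moves the number strongly, and that the methylpyridinyl gives the best result seen. A step well beyond the scatter toward a higher number is therefore expected, a 91-fold higher number from compound 3 to compound 4 (1.96 log units; beyond the scatter). For compound 4 the estimate in this assay is 300 nM, within 40 nM to 3000 nM.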

Compound 4, inhibition constant: 7 nM
Compound 4: middle estimate off by 43-fold (1.63 log units), on the high side; the whole stated range lies above it.
By their numbers in this assay, from the lowest: compound 3; then compound 4; then compound 2; then compound 1.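

In this assay, an aromatic ring on the carbon next to the ring oxygen proves dispensable: methylcarbamoyl, which has no ring, costs only a modest step, a 2.1-fold higher number from compound 3 to compound 4 (0.33 log units; beyond the scatter). The same group also outperforms both substituted phenyl groups, with a 5.7-fold lower number from compound 2 to compound 4 (0.76 log units; beyond the scatter) and a 13-fold lower number from compound 1 to compound 4 (1.11 log units; beyond the scatter), so the presence of a ring does not sort these compounds: compound 3 stays lowest, while compound 2 and compound 1, both with rings, lie above the ringless compound 4. Nothing available bears on the reason for this result.

Going by these compounds, whether the amide hydrogen matters remains open; a dimethylcarbamoyl or a methyl ester on this carbon would test it. Also open, on these data alone, is how a carboxylic acid, or a longer chain on the amide nitrogen, would fare here.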